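Cytotoxicity notes on the shared-core amide series

The source may hold more compounds than are shown below. What is called first, only, known or untested is meant among the compounds shown, and "the series" means these compounds.

compound 1 `CCCC(=O)OCSc1ccccc1C(=O)NC1(C(N)=O)CCCC1`: > 100 uM
compound 2 `CCCC(=O)OCSc1ccccc1C(=O)Nc1cccc(C(N)=O)c1`: 17.5 uM

In an ADME assay on CEM-SS cells (Homo sapiens) for cytotoxicity, read by XTT assay, with a stated time of 6 days (on this read-out lower numbers stand for higher toxicity in this test and higher numbers for lower toxicity in this test), compound 1 gives > 100 uM, which is a limit of the assay rather than a number. Compound 1 therefore stands at the limit of > 100 uM in this assay, at which 1 of the 2 values shown sits. Compound 2 gives 17.5 uM in this assay. Compound 3 `CCCC(=O)OCSc1ccccc1C(=O)NCC(=O)NC` differs from compound 1 by (methylcarbamoyl)methyl in place of 1-carbamoylcyclopentyl on an amide-type nitrogen. Among the compounds with values here, no measured pair covers this change; the step is expected to be none beyond the scatter, so a step that the limit leaves unreadable from compound 1 to compound 3 is the expected step. Compound 3 is expected at 120 uM, between 45 uM and 300 uM, and will most likely again be reported only as a limit.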

Compound 3, half-maximal toxic concentration: > 100 uM
Compound 3: only a limit was reported; the forecaster's own chance of this, stated with the estimate: 70%; the middle value is on the limit's open side.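

Compound 1 and compound 3 both stand only as limits in this assay, so no step can be read between them. The compounds shown leave open whether (methylcarbamoyl)methyl in place of 1-carbamoylcyclopentyl changes the read-out at all.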